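Aryl substituent exchange on the shared core, agonist read-out

The compounds below may be only part of what the source reports. "The series", "measured", "known", "first", "only" and "open" are said of these compounds alone.

compound 1 `Cc1nc(-c2ccccc2)sc1COc1ccc2c(c1)OCC2CC(=O)O`: 54.8%
compound 2 `Cc1nc(-c2cccc(Cl)c2)sc1COc1ccc2c(c1)OCC2CC(=O)O`: 43%

In a functional assay on CHO cells for agonist activity at Free fatty acid receptor 1 (Homo sapiens), read by FLIPR and calcium flux, tested at 100 nM (on this read-out higher numbers stand for a stronger effect at the one concentration tested and lower numbers for a weaker effect), compound 1 gives 54.8% and compound 2 gives 43%. Going by the values given here, compound 2 stands lowest of the two numbers; its nearest neighbour is compound 1, and the single measured step, a number 11.8 percentage points lower from compound 1 to compound 2 (beyond the scatter), lies beyond the scatter.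

Compound 3 `Cc1nc(-c2ccccc2C(F)(F)F)sc1COc1ccc2c(c1)OCC2CC(=O)O` has not been measured in this assay. The change from compound 2 is 2-(trifluoromethyl)phenyl in place of 3-chlorophenyl on an aromatic carbon.

Among the compounds with values here, only one measured step bears on this change: a number 11.8 percentage points lower from compound 1 to compound 2 (beyond the scatter), where a chloro in place of hydrogen on an aromatic carbon cost a modest amount. Within the data shown here, for compound 3 the chlorine leaves and a trifluoromethyl enters at another position of the phenyl; no measured pair covers a trifluoromethyl, so the step from compound 2 cannot be anchored. As far as these compounds go, the removal of the chlorine is expected to recover part of the loss seen in a number 11.8 percentage points lower from compound 1 to compound 2 (beyond the scatter), but the entering group is untested, so the expected step of a number 5 percentage points higher from compound 2 to compound 3 (within the scatter) is small and within the scatter, with wide uncertainty.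

Compound 3 is estimated at 48%, between 30% and 66%.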

Compound 3, a percentage reported as activity, at one concentration (the size of the read-out at that concentration, not a potency): 7.76%
For compound 3 the middle estimate is 40.2 percentage points above the measured one; measured number outside the range, below it.
By their numbers in this assay, from the lowest: compound 3; then compound 2; then compound 1.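

In this assay, this aryl position on the five-membered aromatic ring with 1 nitrogen and 1 sulfur proves far less forgiving than the first pair suggested: 3-chlorophenyl carried only a modest cost, whereas 2-(trifluoromethyl)phenyl gives a number 47 percentage points lower from compound 1 to compound 3 (beyond the scatter), and the exchange of the two substituted aryl groups gives a number 35.2 percentage points lower from compound 2 to compound 3 (beyond the scatter). The read-out at this place therefore depends strongly on what the phenyl carries, where it carries it, or both, and among the three compounds both substituted phenyls fall below the unsubstituted phenyl of compound 1, with none going against that order. No supporting data bear on why the number falls so steeply with this change.

The exchange alters the substituent and its place on the phenyl together, leaving their contributions inseparable; 2-chlorophenyl and 3-(trifluoromethyl)phenyl are the pairings that would divide them. Also open, as far as these compounds go, is whether a methoxy or a nitrile on the phenyl would keep the read-out nearer that of compound 1, and whether the weaker effect of compound 3 at this single concentration would also hold at other concentrations.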